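A carboxylic acid at the end of a thioether chain

This account rests on a few compounds, and the source may have more. Where it says the series, first, only, none or still open, it means among the compounds named here.

Compound 2 `CCCCCCCCCSc1cc(-c2ccccc2)c(-c2ccccc2)nn1` is one of two compounds tested in an assay on microsomes from liver for inhibition of sterol O-acyltransferase 1 (Rattus norvegicus) (on this read-out higher numbers stand for weaker inhibition and lower numbers for stronger inhibition), where compound 2 gives 116000 nM. Compound 1 `CCCCCCCn1nc(-c2ccccc2)c(-c2ccccc2)cc1=O` gives 86000 nM in this assay; the two values lie within the scatter of each other, so neither can be called the stronger inhibitor. Compound 3 `O=C(O)CCCCCCCCSc1cc(-c2ccccc2)c(-c2ccccc2)nn1` has not yet been measured. It differs from compound 2 in one place: carboxy in place of methyl on a saturated chain carbon, eight bonds along the chain from a sulfur. Within the data shown here, no measured pair shows what such a change does here, so only a loose expectation is possible. Compound 3 is expected to give 100000 nM, between 30000 nM and 400000 nM. The expected step of a 1.2-fold lower number from compound 2 to compound 3 (0.06 log units; within the scatter) is therefore small, not confidently beyond the scatter in either direction.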

Compound 3, half-maximal inhibitory concentration: > 300000 nM
Compound 3: a limit, no number (the forecaster's own chance of this, stated with the estimate: 30%); middle value at least 3.0-fold (0.47 log units) from the limit.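

Carboxy in place of methyl on a saturated chain carbon, eight bonds along the chain from a sulfur, is the first single change that can be read here, and in this assay it weakens inhibition, with an at least 2.5-fold higher number from compound 2 to compound 3 (0.41 log units; beyond the scatter). The value of compound 3, > 300000 nM, is a limit and not a number. So the end of this thioether chain is sensitive to this change, though the full size of the loss remains unknown.

From the compounds shown here alone, whether an amine or an ester at the same chain end would fare better remains open. So does whether a shorter chain ending in a carboxylic acid would behave differently.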